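The source may hold more compounds than are shown below. What is called first, only, known or untested is meant among the compounds shown, and "the series" means these compounds.

Working notes on the series.

Compound 1 `COc1cc(C)cc(-c2c(-c3ccnc(-c4ccc(C(C)=O)cc4)c3)cnn2CC#N)c1` is the anchor. In a functional assay on CCRF-CEM cells (Homo sapiens) for inhibition, read by sulforhodamine B assay, with a stated time of 48 h (on this read-out lower numbers stand for higher toxicity in this test and higher numbers for lower toxicity in this test), compound 1 gives > 100000 nM, which is a limit of the assay and not a number. Compound 2 `COc1cc(C)cc(-c2nn(CC#N)cc2-c2ccc(-c3cccc(C(C)=O)c3)nc2)c1` is a close relative on the same core. In this assay compound 2 gives > 100000 nM, again a limit rather than a number. Compound 3 `Cc1cc(O)cc(-c2nn(CC#N)cc2-c2ccnc(-c3ccc(Oc4ccccc4)cc3)c2)c1` carries a hydroxy and a phenoxy group in place of the methoxy and acetyl of compound 1. In this assay compound 3 gives > 100000 nM, also a limit. So compound 1 stands where every measured member stands: the limit of > 100000 nM in this assay, at which 3 of the 3 values shown sit, and no compound in the set has yet produced a numerical readout.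

Compound 4 `COc1cc(C)cc(-c2c(-c3ccnc(-c4ccc(N(C)C)cc4)c3)cnn2CC#N)c1` has not been measured. It differs from compound 1 in one place: dimethylamino in place of acetyl on an aromatic carbon. Among the measured compounds shown here, no measured pair shows this change, so its size cannot be read from the data. Given that compound 1 sits at the limit > 100000 nM, compound 4 is expected to remain in the same region, with a step that the limit leaves unreadable from compound 1 to compound 4 that is expected to be none beyond the scatter. For compound 4 the estimate in this assay is 150000 nM, ranging from 40000 nM to 500000 nM, and most likely the assay will again report only a limit.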

Compound 4, concentration lethal to 50% of the cells: > 100000 nM
Compound 4 was reported as a limit; the forecaster's own chance of this, stated with the estimate: 80%; the middle value is on the limit's open side.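

In this assay compound 4 gives > 100000 nM, a limit and not a number. Among the compounds shown here, compound 1 also sits at a limit, so no step between compound 1 and compound 4 can be read. The compounds shown leave open whether any member of the series gives a numerical readout in this assay: the limit of > 100000 nM in this assay, at which 4 of the 4 values shown sit.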